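One Stereocentre Changed in a Weakly Growth-Inhibiting Series

The compounds below may be only part of what the source reports. "The series", "measured", "known", "first", "only" and "open" are said of these compounds alone.

Compound 1, `C=C1CCCC(C)(C)C1CC[C@]1(C)CC[C@@H]([C@@H](C)C(=O)O)OO1`: 6630 nM
Compound 2, `C=C1CCCC(C)(C)C1(O)CC/C(C)=C/CC[C@]1(C)CC[C@@H]([C@@H](C)C(=O)OC)OO1`: > 17500 nM
Compound 3, `CC1=C(CC/C(C)=C/CC[C@@]2(C)CC[C@@H]([C@H](C)C(=O)O)OO2)C(C)(C)CCC1`: > 100000 nM

In a functional assay on HOP-92 cells (Homo sapiens) for inhibition (a higher number here means a weaker inhibitor of growth, a lower number a stronger inhibitor of growth), compound 1 gives 6630 nM. Compound 2 is reported only as a limit, > 17500 nM, which is the limit of > 17500 nM in this assay, at which 1 of the 3 values shown sits. Compound 3 likewise stands at a limit, > 100000 nM, which is the limit of > 100000 nM in this assay, at which 1 of the 3 values shown sits, the weakest end of what this assay reports. Compound 4, `CC1=C(CC/C(C)=C/CC[C@@]2(C)CC[C@H]([C@H](C)C(=O)O)OO2)C(C)(C)CCC1`, has not yet been tested. Compared with compound 3 the change is the two compounds have the same atoms and bonds and differ only in configuration as drawn: 1 of 4 stereo elements differ; a stereocentre at a saturated ring carbon is drawn S in compound 3 and R in compound 4. Within the data shown here, no measured pair in this set differs in one place, so no step size is known. The change from compound 3 to compound 4 is expected to be a number no higher from compound 3 to compound 4 (the limit leaves the size open), nothing beyond the scatter. Compound 4 is therefore estimated at 100000 nM, between 30000 nM and 100000 nM, and most likely it too will be reported only as a limit.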

Compound 4, concentration for 50% growth inhibition: > 5000 nM
Compound 4 was reported as a limit (the forecaster's own chance of this, stated with the estimate: 75%); the middle value lies beyond the limit too.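

Compound 3 and compound 4 both stand only as limits, so the step between them cannot be read. The compounds shown leave open whether the configuration at that saturated ring carbon affects growth inhibition at all.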